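A few compounds are considered here, and "the series" means these few. Any claim that something is new, unique, unknown or untested is made for them only; others in the source may bear on it.

Measured so far:
compound 1, `CCCSc1nc(Cl)c2c(n1)N(CCNC(=O)OC(C)(C)C)C(C(=O)N1CCN(C)CC1)N2`, in a functional assay on TE-1 cells (Homo sapiens) for antiproliferative activity, read by MTT assay, with a stated time of 72 h (on this read-out higher numbers stand for weaker inhibition and lower numbers for stronger inhibition), gives 51800 nM
compound 2, `CCCSc1nc(Cl)c2c(n1)N(Cc1ccccc1)C(C(=O)OCC)N2`, in this assay gives > 64000 nM, which is a limit of the assay, not a number
compound 3, `CCCSc1nc(Cl)c2c(n1)N(Cc1ccccc1)C(C(=O)N1CCN(C)CC1)N2`, in this assay gives 42500 nM

Compound 3 holds the lowest of the two real numbers, with compound 1 nearest, and that gap, a 1.2-fold lower number from compound 1 to compound 3 (0.09 log units; within the scatter), is within the scatter. Compound 4, `CCCSc1nc(Cl)c2c(n1)N(Cc1ccccc1)C(C(=O)NCCCc1ccccc1)N2`, differs from compound 3 by (3-phenylpropyl)amino in place of 4-methylpiperazin-1-yl on a carbonyl carbon. Going by the values given here, the one measured step at the same place is an at least 1.5-fold lower number from compound 2 to compound 3 (0.17 log units; that floor lies within the scatter), whose floor lies within the scatter; compound 2 rests at the limit (the limit of > 64000 nM in this assay, at which 1 of the 3 values shown sits). Two changes on this carbonyl carbon have so far given no clear movement, so no step beyond the scatter is expected for compound 4, and the estimated step of a 1.1-fold higher number from compound 3 to compound 4 (0.02 log units; within the scatter) is small. Compound 4 is therefore estimated at 45000 nM, in the range 15000 nM to 64000 nM.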

Compound 4, half-maximal inhibitory concentration: 23000 nM
Compound 4: middle estimate off by 2.0-fold (0.29 log units), on the high side; the measured number falls inside the stated range.
By their numbers in this assay, from the lowest: compounds 4, 3 and 1 (each within the scatter of the next, the first and the last beyond it). At a limit, above all of these: compound 2.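

Going by these compounds alone, on this carbonyl carbon, (3-phenylpropyl)amino in place of ethoxy gives the first step here that lies beyond the scatter: an at least 2.7-fold lower number from compound 2 to compound 4 (0.44 log units; beyond the scatter). Compound 2 marks a limit, not a number: the limit of > 64000 nM in this assay, at which 1 of the 4 values shown sits. Against the 4-methylpiperazin-1-yl amide, the same group gives a 1.8-fold lower number from compound 3 to compound 4 (0.27 log units; within the scatter), so these two amides cannot be told apart.

From the compounds shown here alone, what remains open is which part of the new group counts, the amide hydrogen or the phenyl ring. A plain propylamino chain without the ring, or a dimethylamino group without the hydrogen, would separate the two.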